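Moving the bromine on the benzyl group of compound 2

This account rests on a few compounds, and the source may have more. Where it says the series, first, only, none or still open, it means among the compounds named here.

Compound 1, `CCOC(=O)c1cnc(N2CCN(Cc3cccc(C(F)(F)F)c3)CC2)nc1Oc1c(C)cc(-c2ccc(C#N)cc2)cc1C`, in an ADME assay on MT4 cells (Homo sapiens) for cytotoxicity, read by MTT assay, with a stated time of 4 days (on this read-out higher numbers stand for lower toxicity in this test and lower numbers for higher toxicity in this test), reaches only the limit > 125000 nM.
Compound 2, `CCOC(=O)c1cnc(N2CCN(Cc3cccc(Br)c3)CC2)nc1Oc1c(C)cc(-c2ccc(C#N)cc2)cc1C`, in this assay likewise reaches only the limit > 125000 nM.

Compound 2 therefore stands at the limit of > 125000 nM in this assay, at which 2 of the 2 values shown sit, with no number of its own. Among the measured compounds shown here, the one measured step, a step that the two limits leave unreadable from compound 1 to compound 2, cannot be sized for the same reason, so no measured step tells how a change on this benzyl group moves the result.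

Compound 3, `CCOC(=O)c1cnc(N2CCN(Cc3ccccc3Br)CC2)nc1Oc1c(C)cc(-c2ccc(C#N)cc2)cc1C`, is the untested partner; it differs from compound 2 by 2-bromophenyl in place of 3-bromophenyl on a saturated chain carbon bound to an amine nitrogen in a ring. With both neighbours sitting at the limit, compound 3 is expected to give a limit as well, and no readable step beyond the scatter is expected: the expected step is a step that the limit leaves unreadable from compound 2 to compound 3. The estimate for compound 3 in this assay is 150000 nM, within a range from 60000 nM to 400000 nM.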

Compound 3, half-maximal cytotoxic concentration: > 125000 nM
Compound 3 ended at the assay's limit; the forecaster's own chance of this, stated with the estimate: 80%; the middle value does not contradict the limit.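

Compound 1, compound 2 and compound 3 all stop at a limit rather than a number, so no step among them can be read: the limit of > 125000 nM in this assay, at which 3 of the 3 values shown sit.

As far as these compounds go, whether moving the bromine, or replacing trifluoromethyl with bromo, changes the result at all in this assay stays open.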